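The source may hold more compounds than are shown below. What is called first, only, known or untested is meant among the compounds shown, and "the series" means these compounds.

Measured so far in a functional assay on CCRF-CEM cells (Homo sapiens) for cytotoxicity, read by sulforhodamine B assay, with a stated time of 48 h, tested at 1 uM; on this read-out higher numbers stand for a weaker effect at the one concentration tested and lower numbers for a stronger effect:

compound 1 `COc1cc(C)cc(-c2c(-c3ccnc(-c4ccc(C(C)=O)cc4)c3)cnn2CC#N)c1` gives 12%
compound 2 `COc1cc(C)cc(-c2nn(CC#N)cc2-c2ccc(-c3cccc(C(C)=O)c3)nc2)c1` gives 13%
compound 3 `Cc1cc(O)cc(-c2nn(CC#N)cc2-c2ccnc(-c3ccc(Oc4ccccc4)cc3)c2)c1` gives 6%

All three numbers sit low and close together. Compound 1 stands second highest of the three, with compound 2 nearest and compound 3 furthest; both gaps fall within the scatter, so no order among the three can be read from these data, and none of them can be called the strongest or weakest.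

Compound 4 `COc1cc(C)cc(-c2c(-c3ccnc(-c4ccc(N(C)C)cc4)c3)cnn2CC#N)c1` differs from compound 1 in one place: dimethylamino in place of acetyl on an aromatic carbon. The shared core, the nitrile-bearing side chain and the methoxy-methylphenyl arm are unchanged. For the measured compounds named here, no pair of measured compounds differs in exactly this way, so the step has no precedent.

The expectation rests on the narrow spread of compounds 1, 2 and 3: a step in this assay from compound 1 to compound 4 of about a number 3 percentage points higher from compound 1 to compound 4 (within the scatter) is expected, within or only slightly beyond the scatter. Compound 4 is estimated at 15%, within a range from 5% to 40%.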

Compound 4, a percentage reported as activity, at one concentration (the size of the read-out at that concentration, not a potency): 6%
Compound 4: middle estimate off by 9 percentage points, on the high side; low and high end bracket the measured number.
By their numbers in this assay, from the lowest: compounds 3, 4, 1 and 2 (each within the scatter of the next).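

In this assay, for the compounds shown here, the first one-place step reads a number 6 percentage points lower from compound 1 to compound 4 (within the scatter) on going from 4-acetylphenyl to 4-(dimethylamino)phenyl. This aromatic carbon, para to a large group, therefore carries either acetyl or dimethylamino with no change beyond the scatter, even though a carbonyl-bearing group gives way to an amine of the same heavy-atom count. No measured evidence on either group bears on this result, and no cause can be assigned to it.

As far as these compounds go, whether a carboxylic acid, a morpholine or a longer chain at this same carbon would move the number beyond the scatter remains open. From the compounds shown here alone, with only a single concentration tested, the read-out gives no potency, so any difference in potency between compound 1 and compound 4 also remains open.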